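Shortening the link between the two rings of compound 1

The source may hold more compounds than are shown below. What is called first, only, known or untested is meant among the compounds shown, and "the series" means these compounds.

Measured so far:
compound 1, `O=C1NC(=O)C(Cc2ccc(Cc3ccccc3)cc2)S1`, 9280 nM
compound 2, `O=C1NC(=O)C(Cc2ccc(Oc3cccc(C(F)(F)F)n3)cc2)S1`, 1640 nM
compound 3, `O=C1NC(=O)C(Cc2ccc(CCc3ccccc3)cc2)S1`, 1080 nM

In a functional assay for agonist activity at Free fatty acid receptor 1 (Homo sapiens), read by FLIPR, in the presence of a further agent that is not named here (on this read-out higher numbers stand for an effect only at larger amounts of compound and lower numbers for an effect already at smaller amounts), compound 1 gives the highest number of the three, with compound 2 giving 1640 nM and compound 3 giving 1080 nM. For the measured compounds named here, the one step that has been followed from compound 1 lengthens the link between the two rings: an 8.6-fold lower number from compound 1 to compound 3 (0.93 log units; beyond the scatter). Compound 4, `O=C1NC(=O)C(Cc2ccc(-c3ccccc3)cc2)S1`, goes the other way, removing that link altogether: phenyl in place of benzyl on an aromatic carbon. Going by the values given here, no measured pair covers this exact change; the step to compound 3 shows only that a longer link lowers the number, and compound 2, with a different link and a different outer ring, sits between the two. Because compound 1 already gives 9280 nM and the only known direction of gain is toward a longer link, a shorter link is expected to give no gain and possibly a larger number, so the step of a 1.3-fold higher number from compound 1 to compound 4 (0.11 log units; within the scatter) is estimated to be small or upward. Compound 4 is therefore expected to give about 12000 nM in this assay, within a range of 3500 nM to 40000 nM.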

Compound 4, half-maximal effective concentration: 2220 nM
Beside the measured number, compound 4's estimate is 5.4-fold (0.73 log units) above it; the measured number lies below the stated range.
By their numbers in this assay, from the lowest: compounds 3, 2 and 4 (each within the scatter of the next, the first and the last beyond it); then compound 1.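

In this assay, replacing benzyl with phenyl on the aromatic carbon gives a 4.2-fold lower number from compound 1 to compound 4 (0.62 log units; beyond the scatter), so removing the link from compound 1 does not raise the number, as lengthening it might have suggested would happen. Set against an 8.6-fold lower number from compound 1 to compound 3 (0.93 log units; beyond the scatter), this shows that the number falls in both directions from compound 1, which stands highest among compounds 1, 3 and 4; across these three compounds, the number does not follow the length of the link in a single direction. The compounds shown carry no evidence that accounts for this shared fall from compound 1.

On these data alone, compound 2 differs from compound 1 in both its link and its outer ring, so it cannot show what either change does alone, and the effect of an ether oxygen as the link to an unsubstituted phenyl ring remains open. As far as these compounds go, it is also open whether a longer chain than that of compound 3 would carry the number further down, and how a carboxylic acid or an amine on the outer phenyl ring of compound 4 would change it.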